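Allyl Ester to Morpholine Amide: A Forecast for Compound 4

The compounds below may be only part of what the source reports. "The series", "measured", "known", "first", "only" and "open" are said of these compounds alone.

Three compounds carry numbers in an assay on isolated protein for displacement of a labelled ligand from Apoptosis regulator Bcl-2 (Homo sapiens), read by fluorescence polarization; a higher number here means a weaker inhibitor, a lower number a stronger inhibitor. Compound 3 `C=CCOC(=O)[C@H](C)N1C(=O)/C(=C/c2ccc(Br)cc2)SC1=S` gives 192000 nM; compound 1 `C[C@@H](C(=O)O)N1C(=O)/C(=C/c2ccc(Br)cc2)SC1=S` gives 115000 nM, which lies within the scatter of compound 3, while compound 2 `CC(C)C[C@@H](C(=O)O)N1C(=O)C(=C(c2ccccc2)c2ccccc2)SC1=S` gives 57800 nM, a number lower than that of compound 3 by more than the scatter. The one-place step from compound 1 to compound 3, allyl in place of hydrogen on an oxygen next to a carbonyl group, came out as a 1.7-fold higher number from compound 1 to compound 3 (0.22 log units; within the scatter). Compound 4 `C[C@@H](C(=O)N1CCOCC1)N1C(=O)/C(=C/c2ccc(Br)cc2)SC1=S` takes the change (morpholin-4-yl in place of allyloxy on a carbonyl carbon). Among the compounds with values here, no measured step involves a morpholin-4-yl group, and the only step touching this carbonyl carbon stayed within the scatter, so a step of a 1.2-fold lower number from compound 3 to compound 4 (0.08 log units; within the scatter) is expected, with no movement beyond the scatter. Compound 4 is therefore estimated at 160000 nM, within 55000 nM to 450000 nM in this assay.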

Compound 4, inhibition constant: 70000 nM
The estimate for compound 4 lay 2.3-fold (0.36 log units) above the measured number, and the stated range covers the measured number.
By their numbers in this assay, from the lowest: compounds 2, 4, 1 and 3 (each within the scatter of the next, the first and the last beyond it).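

Within the data shown here, at this carbonyl carbon, morpholin-4-yl gave the first step beyond the scatter, a 2.7-fold lower number from compound 3 to compound 4 (0.44 log units; beyond the scatter). Measured against hydroxy on the same carbon, it stayed within the scatter, a 1.6-fold lower number from compound 1 to compound 4 (0.22 log units; within the scatter), so among these three groups only allyloxy and morpholin-4-yl separate. Nothing shown gives a reason for this difference. Still open, on these data alone, is whether piperidin-1-yl or a dimethylamino group on this carbonyl carbon would give a number apart from that of compound 4, and whether morpholin-4-yl would behave alike on the core of compound 2.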